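This account rests on a few compounds, and the source may have more. Where it says the series, first, only, none or still open, it means among the compounds named here.

Three compounds have been measured in a functional assay on HT-29 cells (Homo sapiens) for cytotoxicity, read by sulforhodamine B assay, with a stated time of 2 days, tested at 100 uM; a higher number here means more inhibition at the concentration tested (going by the name of the read-out), a lower number less inhibition:

Compound 1 `O=C(Nn1c(-c2cccc([N+](=O)[O-])c2)nc2c(-c3ccc(Cl)cc3)n[nH]c2c1=O)c1ccccc1`: 87.8%
Compound 2 `O=C(Nn1c(-c2ccccc2)nc2c(-c3ccc(Cl)cc3)n[nH]c2c1=O)c1ccccc1`: 92%
Compound 3 `O=C(Nn1c(CCc2ccccc2)nc2c(-c3ccc(Cl)cc3)n[nH]c2c1=O)c1ccccc1`: 86.5%

The three numbers sit close together. Compound 3 is the one with the smallest number of the three, yet a number 1.3 percentage points lower from compound 1 to compound 3 (within the scatter) and a number 5.5 percentage points lower from compound 2 to compound 3 (within the scatter) are both within the usual scatter, so no real separation between them is shown.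

Compound 4 `CCCCc1nc2c(-c3ccc(Cl)cc3)n[nH]c2c(=O)n1NC(=O)c1ccccc1` differs from compound 3 in one place: ethyl in place of phenyl on a saturated chain carbon, two bonds along the chain from an aromatic carbon.

Among the compounds with values here, no measured step removes the aromatic ring from this chain, so none bears on the change directly. What the measured steps do show is that swapping the group at this position, as in a number 4.2 percentage points higher from compound 1 to compound 2 (within the scatter), a number 1.3 percentage points lower from compound 1 to compound 3 (within the scatter) and a number 5.5 percentage points lower from compound 2 to compound 3 (within the scatter), left this assay essentially unchanged each time. On that basis no step beyond the scatter is expected for compound 4 either, and a number 2.5 percentage points lower from compound 3 to compound 4 (within the scatter) is the expected step. Compound 4 is therefore estimated at 84%, with a range from 65% to 95%.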

Compound 4, a percentage reported as inhibition, at one concentration (the size of the read-out at that concentration, not a potency): 89.5%
Beside the measured number, compound 4's estimate is 5.5 percentage points below it; the measured number falls inside the stated range.
By their numbers in this assay, from the lowest: compounds 3, 1, 4 and 2 (each within the scatter of the next).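

In this assay, cutting the chain from phenethyl to butyl removes its aromatic ring and gives a number 3 percentage points higher from compound 3 to compound 4 (within the scatter), so among these compounds that ring is not shown to matter for the read-out. Butyl, which has no ring, also reads level with the aromatic groups attached directly at this position, with a number 2.5 percentage points lower from compound 2 to compound 4 (within the scatter) and a number 1.7 percentage points higher from compound 1 to compound 4 (within the scatter), which widens the flat picture from ring-bearing groups to a plain saturated chain. No measured evidence here gives a cause for this flatness.

Going by these compounds, the effect of an amine or a carboxylic acid at the end of this chain remains open, as does that of a much longer chain such as octyl. A read-out at a single concentration also leaves open whether these four compounds differ in potency at lower concentrations.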